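The source may hold more compounds than are shown below. What is called first, only, known or untested is meant among the compounds shown, and "the series" means these compounds.

The measured compounds:
compound 1, `Cn1ccc2c(Oc3ccc(NC(=O)c4nn(-c5ccc(Br)cc5F)ccc4=O)cc3)ccnc21`, 20500 nM
compound 2, `Cn1ccc2c(Oc3ccc(NC(=O)c4nn(-c5ccc(Cl)c(F)c5)ccc4=O)cc3)ccnc21`, 32700 nM
compound 3, `Cn1ccc2c(Oc3ccc(NC(=O)c4nn(-c5ccc(Br)cc5F)ccc4=O)cc3F)ccnc21`, 16300 nM

All three were tested in a functional assay on PC-3 cells (Homo sapiens) for cytotoxicity, read by MTT assay, with a stated time of 72 h; a lower number here means a stronger inhibitor, a higher number a weaker inhibitor. Compound 2 differs from compound 1 by 4-chloro-3-fluorophenyl in place of 4-bromo-2-fluorophenyl on an aromatic nitrogen, and the step was a 1.6-fold higher number from compound 1 to compound 2 (0.20 log units; within the scatter). Compound 3 differs from compound 1 by fluoro in place of hydrogen on an aromatic carbon, and the step was a 1.3-fold lower number from compound 1 to compound 3 (0.10 log units; within the scatter). The values of compound 2 and compound 3 lie within the scatter of each other, so nothing can be said of their order.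

Compound 4, `Cn1ccc2c(Oc3ccc(NC(=O)c4nn(-c5ccc(Cl)c(F)c5)ccc4=O)cc3F)ccnc21`, has not yet been measured. It differs from compound 3 by 4-chloro-3-fluorophenyl in place of 4-bromo-2-fluorophenyl on an aromatic nitrogen. This is the same change that takes compound 1 to compound 2, made on the core of compound 3; the two cores differ by fluoro in place of hydrogen on an aromatic carbon.

In this assay, among the compounds with values here, the step from compound 3 to compound 4 is expected to be a 1.6-fold higher number from compound 3 to compound 4 (0.20 log units; within the scatter) because a 1.6-fold higher number from compound 1 to compound 2 (0.20 log units; within the scatter) is the one precedent for this change, and nothing in the data suggests the fluoro on the core alters its size. The estimate for compound 4 is 26000 nM, expected to fall between 13000 nM and 52000 nM.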

Compound 4, half-maximal inhibitory concentration: 17900 nM
Beside the measured number, compound 4's estimate is 1.5-fold (0.16 log units) above it; the measured number falls inside the stated range.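

In this assay, the exchange of 4-bromo-2-fluorophenyl for 4-chloro-3-fluorophenyl on the aromatic nitrogen gave a 1.1-fold higher number from compound 3 to compound 4 (0.04 log units; within the scatter), and fluoro in place of hydrogen on the core gave a 1.8-fold lower number from compound 2 to compound 4 (0.26 log units; within the scatter). The aryl exchange gave steps on the two cores that cannot be told apart: the same change on two cores in this assay, a 1.6-fold higher number (0.20 log units; within the scatter) from compound 1 to compound 2 and a 1.1-fold higher number (0.04 log units; within the scatter) from compound 3 to compound 4, 1.5-fold (0.16 log units) apart, within the scatter of two such steps The fluoro change likewise shows no dependence on its partner group, but every one of these steps lies within the scatter, so the agreement shows only that small steps stayed small, not that either change has a real size that carries from core to core: the same change on two cores in this assay, a 1.3-fold lower number (0.10 log units; within the scatter) from compound 1 to compound 3 and a 1.8-fold lower number (0.26 log units; within the scatter) from compound 2 to compound 4, 1.5-fold (0.16 log units) apart, within the scatter of two such steps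

All four compounds keep a halogen-bearing phenyl on the aromatic nitrogen, so the compounds shown leave open how a larger change would carry across these cores. On these data alone, whether a phenyl bearing an amine or a carboxylic acid in place of the halogens would give a step beyond the scatter, and whether that step would hold on both cores, remains open.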